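Swapping the ring on the hydrazone carbon for a styryl chain

A few compounds are considered here, and "the series" means these few. Any claim that something is new, unique, unknown or untested is made for them only; others in the source may bear on it.

Three compounds share one core and were tested in a functional assay on HCT-116 cells (Homo sapiens) for inhibition, read by MTT assay, with a stated time of 48 h; on this read-out higher numbers stand for weaker inhibition and lower numbers for stronger inhibition. Compound 1 `Fc1ccccc1CSc1nnc(-c2ccncc2)n1-c1ccccc1` gives 12000 nM. Compound 2 `O=C(CSc1nnc(-c2ccncc2)n1-c1ccccc1)N/N=C/c1ccc([N+](=O)[O-])cc1` gives 10200 nM. Compound 3 `O=C(CSc1nnc(-c2ccncc2)n1-c1ccccc1)N/N=C/c1ccccc1F` gives 18000 nM, the highest of the three numbers, yet its gaps to compound 1 and to compound 2 both lie within the usual scatter, so no order among them can be read.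

Compound 4 `O=C(CSc1nnc(-c2ccncc2)n1-c1ccccc1)N/N=C/C=C/c1ccccc1` is not yet measured. It differs from compound 3 by one change: 2-phenylethenyl in place of 2-fluorophenyl on a carbon with a double bond to nitrogen. Going by the values given here, the only measured step that bears on this change is the swap of one ring for another on the same carbon, which gave a 1.8-fold higher number from compound 2 to compound 3 (0.25 log units; within the scatter), a move within the scatter. Among the compounds with values here, nothing more is known about this position; no step to a chain with a double bond has been measured. On that basis no step beyond the scatter is expected, and the estimated change is a 1.3-fold lower number from compound 3 to compound 4 (0.11 log units; within the scatter). Compound 4 is therefore expected to give about 14000 nM in this assay, with a likely range from 5000 nM to 40000 nM.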

Compound 4, half-maximal inhibitory concentration: 6150 nM
Compound 4: the middle estimate sits 2.3-fold (0.36 log units) above what was measured; low and high end bracket the measured number.
By their numbers in this assay, from the lowest: compounds 4, 2, 1 and 3 (each within the scatter of the next, the first and the last beyond it).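

Going by these compounds alone, putting the 2-phenylethenyl chain in place of a ring on a carbon with a double bond to nitrogen gives, in this assay, a 2.9-fold lower number from compound 3 to compound 4 (0.47 log units; beyond the scatter) and is the first step at this position to lie beyond the scatter, which shows that the number here can respond to the group carried. The step is modest and depends on the ring it is compared with: the same kind of swap gives a 1.7-fold lower number from compound 2 to compound 4 (0.22 log units; within the scatter) and stays within the scatter, so 2-phenylethenyl stands apart from 2-fluorophenyl but not from 4-nitrophenyl. The data shown offer no explanation for this step.

Whether the double bond of the chain matters remains open, since the compounds shown include no saturated 2-phenylethyl chain for comparison. Also open, as far as these compounds go, is how a longer chain, or an amine or a carboxylic acid on the chain's phenyl ring, would change the number.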